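Swapping the sulfonyl aryl group in a tracheal antagonist series

A few compounds are considered here, and "the series" means these few. Any claim that something is new, unique, unknown or untested is made for them only; others in the source may bear on it.

Measured so far:
compound 1 `COc1cc(C(=O)NS(=O)(=O)c2cccs2)ccc1Cn1ccc2ccc(NC(=O)CC3CCCC3)cc21` gives 9.6
compound 2 `COc1cc(C(=O)NS(=O)(=O)c2ccccc2C)ccc1Cn1ncc2ccc(NC(=O)CC3CCCC3)cc21` gives 10.9

Compound 1 is the weaker of the two in a functional assay (trachea) for antagonist activity, with Cavia porcellus as the target (on this read-out higher numbers stand for higher potency (the scale is a negative logarithm) and lower numbers for lower potency), with compound 2 standing higher and well beyond the scatter; these two compounds differ in more than one place, so their values are simply noted. Compound 3 `COc1cc(C(=O)NS(=O)(=O)c2ccccc2Cl)ccc1Cn1ccc2ccc(NC(=O)CC3CCCC3)cc21` carries the change (2-chlorophenyl in place of thiophen-2-yl on a sulfonyl sulfur). Among the measured compounds shown here, no measured pair isolates this change, so only a small step is expected from it: a number 0.20 log units higher from compound 1 to compound 3 (within the scatter), a shift that should stay within the scatter. Compound 3 is therefore estimated at 9.8, between 9.2 and 10.4.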

Compound 3, negative logarithm of the antagonist equilibrium constant: 9.8
Compound 3: middle estimate and measured number agree at the digits printed, within the range that was stated.
By their numbers in this assay, from the lowest: compounds 1 and 3 (each within the scatter of the next); then compound 2.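

Placing 2-chlorophenyl in place of thiophen-2-yl on the sulfonyl sulfur leaves the number in this assay inside the usual scatter (a number 0.20 log units higher from compound 1 to compound 3 (within the scatter)). This position therefore accepts a five-membered aromatic ring with sulfur and a six-membered carbon ring bearing chlorine, and the two compounds cannot be told apart here. Nothing available explains why these two groups read alike.

As far as these compounds go, what the chlorine contributes on its own remains open. So does how an unsubstituted phenyl, or a simple methyl, would read on the same sulfur.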